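The compounds below may be only part of what the source reports. "The series", "measured", "known", "first", "only" and "open" are said of these compounds alone.

Series notes on the shared core of compound 1 `Cc1cc(C)cc(S(=O)(=O)c2c(C(=O)NC3CNC3)[nH]c3ccc(Cl)cc23)c1`. In an ADME assay on MT4 cells (Homo sapiens) for cytotoxicity, read by MTT assay, with a stated time of 5 days (on this read-out higher numbers stand for lower toxicity in this test and lower numbers for higher toxicity in this test), compound 1 gives 37300 nM. Compound 2 `Cc1cc(C)cc(S(=O)(=O)c2c(C(=O)N[C@@H]3CCN(S(C)(=O)=O)C3)[nH]c3ccc(Cl)cc23)c1` gives 24000 nM, and compound 3 `Cc1cc(C)cc(S(=O)(=O)c2c(C(=O)NC3CN(Cc4cccnc4)C3)[nH]c3ccc(Cl)cc23)c1` gives 36000 nM. Compound 3 holds the second highest of the three numbers: its nearest neighbour is compound 1, a 1.0-fold lower number from compound 1 to compound 3 (0.02 log units; within the scatter), and its furthest is compound 2, a 1.5-fold higher number from compound 2 to compound 3 (0.18 log units; within the scatter). The remaining step, a 1.6-fold lower number from compound 1 to compound 2 (0.19 log units; within the scatter), is also within the scatter, so the three measured compounds show no separation in this assay.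

The next compound, compound 4 `Cc1cc(C)cc(S(=O)(=O)c2c(C(=O)NS(=O)(=O)C(F)(F)F)[nH]c3ccc(Cl)cc23)c1`, is not yet measured. (trifluoromethyl)sulfonyl in place of 1-((pyridin-3-yl)methyl)azetidin-3-yl on an amide-type nitrogen The change sits on the amide-type nitrogen whose other neighbour is the carbonyl carbon, the same place varied in a 1.6-fold lower number from compound 1 to compound 2 (0.19 log units; within the scatter) and a 1.5-fold higher number from compound 2 to compound 3 (0.18 log units; within the scatter), both within the scatter. Within the data shown here, a (trifluoromethyl)sulfonyl group at this position has no precedent among the measured compounds, so the uncertainty is wider than those steps suggest, but because a 1.5-fold higher number from compound 2 to compound 3 (0.18 log units; within the scatter) and a 1.6-fold lower number from compound 1 to compound 2 (0.19 log units; within the scatter) each stayed within the scatter, no step beyond the scatter is expected for compound 4, an expected step of a 1.2-fold lower number from compound 3 to compound 4 (0.08 log units; within the scatter). The estimate for compound 4 in this assay is 30000 nM, with an expected range from 10000 nM to 90000 nM.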

Compound 4, half-maximal cytotoxic concentration: 141000 nM
For compound 4 the middle estimate is 4.7-fold (0.67 log units) below the measured one; measured number above the stated range.
By their numbers in this assay, from the lowest: compounds 2, 3 and 1 (each within the scatter of the next); then compound 4.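

In this assay the amide-type nitrogen no longer looks indifferent to its substituent, since the replacement of each earlier group by (trifluoromethyl)sulfonyl moves the number beyond the scatter (a 3.9-fold higher number from compound 3 to compound 4 (0.59 log units; beyond the scatter)) (a 3.8-fold higher number from compound 1 to compound 4 (0.58 log units; beyond the scatter)) (a 5.9-fold higher number from compound 2 to compound 4 (0.77 log units; beyond the scatter)). The three earlier groups, azetidin-3-yl, 1-(methylsulfonyl)pyrrolidin-3-yl and 1-((pyridin-3-yl)methyl)azetidin-3-yl, could not be told apart here, whereas (trifluoromethyl)sulfonyl stands apart from all three, on the side of lower toxicity in this test. Nothing available explains this shift.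

Open, on these data alone, is whether the higher number stays with a simple methylsulfonyl or a phenylsulfonyl on this same nitrogen, or instead follows the trifluoromethyl, as a trifluoroacetyl group would test. Also open, as far as these compounds go, is whether the step carries over when the chloro or dimethylphenyl parts of the shared core are changed.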